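The compounds below may be only part of what the source reports. "The series", "measured", "known", "first", "only" and "open" are said of these compounds alone.

Of the compounds shown here, three sharing one core have been measured in a functional assay on HGC-27 cells (Homo sapiens) for inhibition, read by MTT assay, with a stated time of 72 h; a higher number here means a weaker inhibitor, a lower number a stronger inhibitor. Compound 1 `Cc1cc(N2CC[C@@H](C)[C@@H](N(C)c3ncnc4[nH]ccc34)C2)n2nc(SCCc3ccccc3)nc2n1` gives 11800 nM. Compound 2 `Cc1cc(N2CC[C@@H](C)[C@@H](N(C)c3ncnc4[nH]ccc34)C2)n2nc(SCc3ccc(Br)cc3)nc2n1` gives 19500 nM. Compound 3 `Cc1cc(N2CC[C@@H](C)[C@@H](N(C)c3ncnc4[nH]ccc34)C2)n2nc(SCc3ccc([N+](=O)[O-])cc3)nc2n1` gives 29400 nM, the highest of the three numbers; its nearest neighbour is compound 2, at a distance within the scatter, while the gap to compound 1 is beyond it, as a 2.5-fold higher number from compound 1 to compound 3 (0.40 log units; beyond the scatter).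

Compound 4 `Cc1ccc(CSc2nc3nc(C)cc(N4CC[C@@H](C)[C@@H](N(C)c5ncnc6[nH]ccc56)C4)n3n2)cc1` differs from compound 3 in one place: methyl in place of nitro on an aromatic carbon. Among the compounds with values here, two measured steps bear on this. Exchanging the group in the same position gave a 1.5-fold higher number from compound 2 to compound 3 (0.18 log units; within the scatter), which is within the scatter. Adding the nitro group to the bare benzyl gave a 2.5-fold higher number from compound 1 to compound 3 (0.40 log units; beyond the scatter), a modest but real rise. Since a methyl is small and uncharged like the bare benzyl, a modest move back toward a lower number is expected for compound 4 in this assay, a 1.6-fold lower number from compound 3 to compound 4 (0.21 log units; within the scatter), though a step within the scatter would not surprise.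

The estimate for compound 4 in this assay is therefore 18000 nM, with a likely range from 9000 nM to 40000 nM.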

Compound 4, half-maximal inhibitory concentration: 15200 nM
For compound 4 the middle estimate is 1.2-fold (0.07 log units) above the measured one; low and high end bracket the measured number.
By their numbers in this assay, from the lowest: compounds 1, 4, 2 and 3 (each within the scatter of the next, the first and the last beyond it).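

In this assay, methyl in place of nitro gives a 1.9-fold lower number from compound 3 to compound 4 (0.29 log units; within the scatter), and methyl in place of bromo gives a 1.3-fold lower number from compound 2 to compound 4 (0.11 log units; within the scatter), so methyl, bromo and nitro cannot be told apart at this aromatic carbon, para to a large group. On the other side, 4-methylphenyl in place of benzyl gives a 1.3-fold higher number from compound 1 to compound 4 (0.11 log units; within the scatter), which places compound 4 within the scatter of all three earlier compounds, and the gap between compound 1 and compound 3 remains the only one beyond it. Nothing measured here explains these small differences.

Going by these compounds, it remains open whether an amine or a carboxylic acid at this aromatic carbon would give a step beyond the scatter. A longer chain to the sulfur is also untested alongside the 4-methylphenyl group.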